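The source may report more compounds than this note shows. Statements on the series, on what has been measured and on what is new or still open speak of the compounds shown alone.

Working notes on the series. Compound 1 `CC(C)(C)c1ccc(C(=O)NCc2ccc(NS(=O)(=O)C(F)(F)F)cc2Cl)cc1` in an ADME assay on microsomes from liver (Rattus norvegicus, strain Sprague-Dawley) for metabolic stability, read by HPLC, using NADPH, with stated times of 5 min and 60 min, tested at 10 uM (on this read-out lower numbers stand for a shorter-lived compound and higher numbers for a longer-lived compound), gives 1.3 h. Compound 2 `CN(C)c1ccc(C(=O)NCc2ccc(NS(C)(=O)=O)cc2Cl)cc1` in this assay gives 0.883 h. Only these two compounds have been measured, and the gap between compound 2 and compound 1 lies within the usual scatter of this assay, so the two cannot be told apart; compound 2 stands, on the numbers available, at essentially the same level as compound 1.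

The next compound to be run is compound 3 `COC(C)(C)c1ccc(C(=O)NCc2ccc(NS(C)(=O)=O)cc2Cl)cc1`, which differs from compound 2 in one place: 1-methoxy-1-methylethyl in place of dimethylamino on an aromatic carbon.

Within the data shown here, no step between two measured compounds covers this change, so there is nothing in the data that points in either direction. For the step from compound 2 to compound 3 the expected shift is a 1.1-fold higher number from compound 2 to compound 3 (0.05 log units; within the scatter), that is, none beyond the scatter. Compound 3 is therefore estimated to give 1 h in this assay, with a range from 0.5 h to 2.5 h.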

Compound 3, half-life: 0.917 h
Estimate against measurement, compound 3: 1.1-fold (0.04 log units) above; low and high end bracket the measured number.
By their numbers in this assay, from the lowest: compounds 2, 3 and 1 (each within the scatter of the next).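

Among these compounds, on the aromatic carbon para to a large group, this is the first single-place change that can be read in this assay: 1-methoxy-1-methylethyl in place of dimethylamino gives a 1.0-fold higher number from compound 2 to compound 3 (0.02 log units; within the scatter) and so cannot be told apart from the group it replaces. At this position, then, dimethylamino and 1-methoxy-1-methylethyl, with 3 and 5 heavy atoms and 1 hydrogen-bond acceptor each, give half-lives within the scatter of each other. No measurement at hand speaks to the reason for this result.

From the compounds shown here alone, how a carboxylic acid or a longer alkyl chain at this position would read remains open. Also open, going by these compounds, is whether the same holds with the trifluoromethyl group of compound 1, which differs from compound 3 in more than one place.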